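Series notes: phenyl for trifluoromethyl on the core carbon

A few compounds are considered here, and "the series" means these few. Any claim that something is new, unique, unknown or untested is made for them only; others in the source may bear on it.

Compound 1 `C[C@H](NC(=O)c1nnn(Cc2ccc(C(F)(F)F)cc2)c1C(F)(F)F)c1ccc(C(=O)O)cc1` is the reference point of the set. In a functional assay on CHO cells for antagonist activity at prostaglandin E2 receptor EP4 subtype (Homo sapiens), read by calcium flux, with a stated time of 15 min (a higher number here means a weaker inhibitor, a lower number a stronger inhibitor), compound 1 gives > 10000 nM, which is a limit of the assay and not a number. Compound 2 `C[C@H](NC(=O)c1nnn(CCOc2ccc(F)cc2)c1C(F)(F)F)c1ccc(C(=O)O)cc1` carries (4-fluorophenoxy)methyl in place of 4-(trifluoromethyl)phenyl on a saturated chain carbon bound to an aromatic nitrogen; in this assay compound 2 gives > 10000 nM, again a limit. Compound 3 `CCCc1c(C(=O)N[C@@H](C)c2ccc(C(=O)O)cc2)nnn1Cc1ccc(C(F)(F)F)cc1` has propyl in place of trifluoromethyl on an aromatic carbon; in this assay compound 3 gives > 10000 nM, also a limit. The two measured steps, a step that the two limits leave unreadable from compound 1 to compound 2 and a step that the two limits leave unreadable from compound 1 to compound 3, cannot be sized because of the limit of > 10000 nM in this assay, at which 3 of the 3 values shown sit.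

Compound 4 `C[C@H](NC(=O)c1nnn(Cc2ccc(C(F)(F)F)cc2)c1-c1ccccc1)c1ccc(C(=O)O)cc1` differs from compound 1 by phenyl in place of trifluoromethyl on an aromatic carbon. Among the measured compounds shown here, the measured step closest to it is the one from compound 1 to compound 3, which exchanges the same trifluoromethyl for another carbon group at that aromatic carbon, yet its size is unreadable. No direction or size for this step in this assay can be drawn from what is shown; nothing in the set moves off the limit. Compound 4 is therefore expected to stay close to the limit, with the step from compound 1 estimated as a number no higher from compound 1 to compound 4 (the limit leaves the size open). The estimate for compound 4 in this assay is 10000 nM, within 2000 nM to 50000 nM.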

Compound 4, half-maximal inhibitory concentration: > 10000 nM
Compound 4 ended at the assay's limit; the forecaster's own chance of this, stated with the estimate: 65%; the middle value lies on the limit itself.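

No new step can be read for compound 4 against compound 1 or compound 3, because all of these values stand at one limit of this assay and none is a number: the limit of > 10000 nM in this assay, at which 4 of the 4 values shown sit.

The compounds shown leave open whether any group on the shared core gives a readable inhibitory concentration, and which group would do so.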